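The source may hold more compounds than are shown below. What is called first, only, known or untested is meant among the compounds shown, and "the series" means these compounds.

Compound 1 `O=C(NCCCCc1ccccc1)n1cc(-c2ccc(Cl)cc2)oc1=O` and compound 2 `O=C(NCCCCc1ccccc1)n1cc(-c2ccc(F)cc2)oc1=O` share a core and a four-carbon chain ending in a phenyl group, and differ only in the halogen on the aromatic ring. In an assay on isolated protein for inhibition of acid ceramidase (Homo sapiens), read by LC-MS, with a stated time of 1 h (on this read-out higher numbers stand for weaker inhibition and lower numbers for stronger inhibition), compound 1 gives 83 nM, and compound 2 gives 185 nM. Going by the values given here, the only step in hand is a 2.2-fold higher number from compound 1 to compound 2 (0.35 log units; beyond the scatter), so compound 2 has the highest number of the two measured compounds, with compound 1 the nearer and only neighbour.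

Compound 3 `CN1CCC(c2cc(F)ccc2-c2cn(C(=O)NCCCCc3ccccc3)c(=O)o2)CC1` takes compound 2 one step further: 1-methylpiperidin-4-yl in place of hydrogen on an aromatic carbon. Among the compounds with values here, no measured step involves a group of this kind or a change at this place, so the step from compound 1 to compound 2, which concerned only the halogen, does not bear on it directly. Without a comparable step the direction of the change in this assay cannot be read from the data, and a step of modest size in either direction, or none beyond the scatter, is what one would expect, written as a 1.1-fold higher number from compound 2 to compound 3 (0.03 log units; within the scatter). On that basis compound 3 is estimated at 200 nM in this assay, within a range of 60 nM to 700 nM.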

Compound 3, half-maximal inhibitory concentration: 337 nM
Beside the measured number, compound 3's estimate is 1.7-fold (0.23 log units) below it; the measured number falls inside the stated range.
By their numbers in this assay, from the lowest: compound 1; then compounds 2 and 3 (each within the scatter of the next).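

Going by these compounds alone, the step gives a first reading at a new place on the aromatic ring: in this assay, putting 1-methylpiperidin-4-yl in place of hydrogen on an aromatic carbon, ortho to a large group and meta to a fluoro group, gives a 1.8-fold higher number from compound 2 to compound 3 (0.26 log units; within the scatter) and so leaves the two compounds level on this read-out. The earlier pair spoke only of the halogen, whereas this change shows that a group of 7 heavy atoms, carrying a six-membered non-aromatic ring with one nitrogen, can take the place of a hydrogen atom here with no change beyond the scatter. Nothing on hand gives a reason for this outcome.

As far as these compounds go, what this aromatic carbon would do with a piperidin-4-yl group lacking the methyl on its nitrogen, with a morpholine ring, with a smaller methyl group or with a carboxylic acid stays open. Also open, from the compounds shown here alone, is whether 1-methylpiperidin-4-yl would give a similar step with chloro in place of fluoro on the same ring, since a single pair cannot show how far this result extends.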